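Pyridyl swap on the alkyne aryl of compound 1

The source may report more compounds than this note shows. Statements on the series, on what has been measured and on what is new or still open speak of the compounds shown alone.

Compound 1 `O=C(NC1CCCC1)c1ccc(C#Cc2ccccc2)nc1` is the reference point. Within the data shown here, in a functional assay on HEK293 cells for positive allosteric modulation of metabotropic glutamate receptor 5 (Homo sapiens), read by FLIPR and calcium flux (a higher number here means that more compound is needed for the effect, a lower number that less compound is needed), compound 1 gives 19 nM, the lowest of the two numbers so far. Its nearest neighbour is compound 2 `CC(C)NC(=O)c1ccc(C#Cc2ccccc2)nc1`, which in this assay gives 62 nM; the step of a 3.3-fold higher number from compound 1 to compound 2 (0.51 log units; beyond the scatter) concerns only the substituent on the amide nitrogen. Compound 3 `O=C(NC1CCCC1)c1ccc(C#Cc2cccnc2)nc1` differs from compound 1 elsewhere: pyridin-3-yl in place of phenyl on a triple-bonded carbon. Among the measured compounds shown here, no measured step touches the aryl on the triple-bonded carbon, so the amide step from compound 1 to compound 2 does not bear on this change, and the series gives no direct guidance on its size or direction. Absent such a precedent, a small shift in this assay, within the scatter or a modest rise, is the working expectation, written as a 2.1-fold higher number from compound 1 to compound 3 (0.32 log units; beyond the scatter). Compound 3 is therefore estimated at 40 nM in this assay, with a range of 8 nM to 200 nM.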

Compound 3, half-maximal effective concentration: > 10000 nM
Compound 3 was reported as a limit; the forecaster's own chance of this, stated with the estimate: 5%; middle value at least 250-fold (2.39 log units) away from the limit.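

In this assay, pyridin-3-yl in place of phenyl on a triple-bonded carbon gives an at least 520-fold higher number from compound 1 to compound 3 (2.72 log units; beyond the scatter), against a 3.3-fold higher number from compound 1 to compound 2 (0.51 log units; beyond the scatter) for the change on the amide nitrogen, so the aryl is the more sensitive of the two places varied so far. As far as these compounds go, compound 3 gives > 10000 nM, which is a limit of the assay and not a number, so the step is a lower bound and its true size stays unknown. With the heavy-atom count unchanged, one ring nitrogen in place of a ring carbon separates a measurable value from a limit: the limit of > 10000 nM in this assay, at which 1 of the 3 values shown sits.

From the compounds shown here alone, whether the ring nitrogen as such or its place in the ring decides the outcome stays open; a pyridin-2-yl or pyridin-4-yl group on the same carbon would separate the two. Also open, going by these compounds, is whether a fluoro or methyl group on the phenyl ring keeps the value of compound 1 in range.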